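This account rests on a few compounds, and the source may have more. Where it says the series, first, only, none or still open, it means among the compounds named here.

Measured so far in an assay on Sf9 cells for inhibition of mitogen-activated protein kinase kinase kinase 14 variant S549D (Homo sapiens), with a stated time of 30 min, in the presence of a further agent that is not named here; a higher number here means a weaker inhibitor, a lower number a stronger inhibitor:
compound 1 `C=CC(=O)NCCCCc1ccc2ncn(-c3ccnc(N)n3)c2c1`: 501000 nM
compound 2 `CC(=O)NCCCCc1ccc2ncn(-c3ccnc(N)n3)c2c1`: 398000 nM
compound 3 `C#Cc1cncc(C#Cc2ccc3ncn(-c4ccnc(N)n4)c3c2)c1`: 63100 nM

Compound 3 has the lowest number of the three in this assay; both compound 1 and compound 2 sit clearly higher, so compound 3 is the strongest inhibitor shown. Compound 4 `C#Cc1cnc(C#Cc2ccc3ncn(-c4ccnc(N)n4)c3c2)nc1` differs from compound 3 in one place: a group of 8 heavy atoms (6 carbon, 2 nitrogen; one six-membered aromatic ring with 2 hetero atoms) in place of a group of 8 heavy atoms (7 carbon, 1 nitrogen; one six-membered aromatic ring with 1 hetero atom), on a triple-bonded carbon. Within the data shown here, the only measured step, a 1.3-fold lower number from compound 1 to compound 2 (0.10 log units; within the scatter), concerns the amide end of a different side chain and carries no information on a ring exchange at a triple-bonded carbon, so no bearing step exists. With no guidance on this change, a step of about a 1.3-fold higher number from compound 3 to compound 4 (0.10 log units; within the scatter) is expected, within the scatter. Compound 4 is therefore estimated at 80000 nM, in the range 25000 nM to 250000 nM.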

Compound 4, half-maximal inhibitory concentration: 25100 nM
For compound 4 the middle estimate is 3.2-fold (0.50 log units) above the measured one; the range from low to high includes it.
By their numbers in this assay, from the lowest: compound 4; then compound 3; then compounds 2 and 1 (each within the scatter of the next).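

At the triple-bonded carbon, the group with 2 hetero atoms in its six-membered aromatic ring gives a 2.5-fold lower number from compound 3 to compound 4 (0.40 log units; beyond the scatter) in this assay. Among these compounds, this is the first step that lies beyond the scatter for an exchange of one ring for another at this place, though it is modest. No measurement shown accounts for this step.

On these data alone, how an amine or a carboxylic acid on the triple-bonded carbon would compare remains open. As far as these compounds go, compound 4 gives 25100 nM, and also open is whether any group there would take the number far lower.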